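Chlorobenzyl position in a Substance-P receptor binding series

A few compounds are considered here, and "the series" means these few. Any claim that something is new, unique, unknown or untested is made for them only; others in the source may bear on it.

Measured compounds:
Compound 1, `O=C(CCc1cc(C(F)(F)F)cc(C(F)(F)F)c1)N(Cc1ccccc1Cl)C1CCNCC1`: 100 nM
Compound 2, `O=C(COc1cc(C(F)(F)F)cc(C(F)(F)F)c1)N(Cc1ccccc1Cl)C1CCNCC1`: 126 nM
Compound 3, `Cc1cc(C)cc(OCC(=O)N(Cc2cccc(Cl)c2)C2CCNCC2)c1`: 100 nM

The three compounds were tested in an assay on CHO cells for binding affinity to Substance-P receptor (Homo sapiens); a higher number here means a weaker inhibitor, a lower number a stronger inhibitor. Compound 2 gives 126 nM, the highest of the three numbers, but its nearest neighbour, compound 1, gives 100 nM, and compound 3 gives 100 nM; both lie within the scatter of compound 2, so the three read as equal within the precision of this assay.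

Compound 4, `O=C(COc1cc(C(F)(F)F)cc(C(F)(F)F)c1)N(Cc1cccc(Cl)c1)C1CCNCC1`, has not yet been measured. It differs from compound 2 in one place: 3-chlorophenyl in place of 2-chlorophenyl on a saturated chain carbon bound to an amide-type nitrogen. Compound 3 carries the same 3-chlorobenzyl group on a different aromatic part and gives 100 nM, while compound 2 with the 2-chlorobenzyl group gives 126 nM; these two values are within the scatter of each other. Going by the values given here, no single-point step between measured compounds is known for this change, so the size of the step from compound 2 to compound 4 is estimated at none beyond the scatter, in either direction. Compound 4 is therefore expected to give about 110 nM in this assay, with a likely range from 40 nM to 350 nM, an expected step of a 1.1-fold lower number from compound 2 to compound 4 (0.06 log units; within the scatter).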

Compound 4, half-maximal inhibitory concentration: 25.1 nM
The estimate for compound 4 lay 4.4-fold (0.64 log units) above the measured number, outside the stated range (below it).
By their numbers in this assay, from the lowest: compound 4; then compounds 1, 3 and 2 (each within the scatter of the next).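

In this assay, 3-chlorophenyl in place of 2-chlorophenyl on a saturated chain carbon bound to an amide-type nitrogen gives a 5.0-fold lower number from compound 2 to compound 4 (0.70 log units; beyond the scatter), which shows that the placing of the chlorine on this benzyl group matters in this series. The earlier compounds shown here could not show this: their values lay within the scatter of one another, and no two of them differed in this one place. As the two compounds have the same atoms, joined differently, the step comes from this one change on an otherwise unchanged structure, although nothing available explains why the change has an effect of this size.

The compounds shown leave open whether the step is specific to the core of compound 2 or would also appear on the core of compound 1, which carries the 2-chlorobenzyl group on a different chain and has no 3-chlorobenzyl partner here. They also leave open how this position would respond to a plain benzyl, a bromobenzyl or a methoxybenzyl group, so a single change of place is all that is known about it.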